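Antiproliferative series: isopropyl for dimethoxypropyl on ring nitrogen

This account rests on a few compounds, and the source may have more. Where it says the series, first, only, none or still open, it means among the compounds named here.

Measured so far:
compound 1 `Nc1ccccc1NC(=O)c1ccc(Cn2cnc3c(Nc4cccc(OC(F)(F)F)c4)nc(Cl)nc32)cc1`: 1.6%
compound 2 `COC(CCn1cnc2c(NCc3ccc(C(=O)Nc4ccccc4N)cc3)nc(Cl)nc21)OC`: 6.39%
compound 3 `CC(C)n1cnc2c(Nc3ccccc3)nc(NCOCc3ccc(C(=O)Nc4ccccc4N)cc3)nc21`: 6.85%

All three were run in a functional assay on HCT-116 cells (Homo sapiens) for antiproliferative activity, read by CCK-8 assay, with a stated time of 72 h, tested at 2 uM; on this read-out higher numbers stand for a stronger effect at the one concentration tested and lower numbers for a weaker effect. Compound 1 gives 1.6%, compound 2 gives 6.39% and compound 3 gives 6.85%. On these numbers compound 2 stands second of three; its nearest neighbour is compound 3, a gap within the scatter, and the furthest is compound 1, also within the scatter. For the measured compounds named here, the three values therefore cannot be told apart, and no single-change step between measured compounds is available.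

Compound 4 `CC(C)n1cnc2c(NCc3ccc(C(=O)Nc4ccccc4N)cc3)nc(Cl)nc21` has not yet been measured. It differs from compound 2 as follows: isopropyl in place of 3,3-dimethoxypropyl on an aromatic nitrogen. The change sits on an aromatic nitrogen of a five-membered aromatic ring with two nitrogens, part of a fused system of two rings.

Nothing in the measured set bears on this change. Given that the three measured compounds fall within the scatter of one another, the step from compound 2 to compound 4 is expected to be a number 0.4 percentage points lower from compound 2 to compound 4 (within the scatter), that is, nothing beyond the scatter in either direction. Compound 4 is expected to give about 6%, with a range from 0% to 18%.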

Compound 4, a percentage reported as inhibition, at one concentration (the size of the read-out at that concentration, not a potency): 73.2%
For compound 4 the middle estimate is 67.2 percentage points below the measured one, and the stated range ends below it.
By their numbers in this assay, from the lowest: compounds 1, 2 and 3 (each within the scatter of the next); then compound 4.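

In this assay, for the compounds shown here, the group on this ring nitrogen proves to be a strong determinant of the read-out: with the rest of compound 2 unchanged, isopropyl in place of 3,3-dimethoxypropyl gives a number 66.8 percentage points higher from compound 2 to compound 4 (beyond the scatter) and this is the only single-place step so far. The earlier compounds shown here lay within the scatter of one another and shared no single-place step, so they could not show that this aromatic nitrogen of the five-membered ring responds to substitution at all. No measurement at hand accounts for the size of this step.

Going by these compounds, it remains open whether the gain belongs to isopropyl itself or to the loss of the 3,3-dimethoxypropyl chain, a question that a cyclopentyl ring, a plain n-propyl chain or a 3-hydroxypropyl chain on the same nitrogen would help to settle. Also open, on these data alone, is how far the step holds elsewhere, and what it means for potency, since each read-out here comes from one concentration and gives the size of the effect at that concentration only.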